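The compounds below may be only part of what the source reports. "The series", "measured", "known", "first", "only" and "open" are said of these compounds alone.

Measured in a functional assay on the whole organism for inhibition, with Mus musculus as the target; on this read-out higher numbers stand for an effect only at larger amounts of compound and lower numbers for an effect already at smaller amounts:

- compound 1 `CCC1(C)CCOC1=O`: 259 mg/kg
- compound 2 `CC1CCSC1=O`: 91 mg/kg
- compound 3 `CCC1CCSC1=O`: 414 mg/kg

The values of compound 3 and compound 1 lie within the usual scatter of each other, so they cannot be told apart. Compound 2 stands clearly apart from compound 3, with a 4.5-fold higher number from compound 2 to compound 3 (0.66 log units; beyond the scatter).

The next structure is compound 4 `CC(C)C1CCSC1=O`, in which ethyl becomes isopropyl: methyl in place of hydrogen on a saturated chain carbon bound to a saturated chain carbon and a saturated ring carbon. This places methyl in place of hydrogen on a saturated chain carbon bound to a saturated chain carbon and a saturated ring carbon.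

Only one measured step bears on this change, the one from compound 2 to compound 3 described above. It also added a methyl, but at a different place, on a saturated chain carbon bound to a saturated ring carbon. One step at another place is thin evidence, so in this assay a shift in the same direction is expected, though smaller and possibly within the scatter. The estimated step is a 1.3-fold higher number from compound 3 to compound 4 (0.10 log units; within the scatter). The estimated value for compound 4 is 520 mg/kg, with an expected range from 210 mg/kg to 1250 mg/kg.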

Compound 4, dose for half-maximal effect: 145 mg/kg
For compound 4 the middle estimate is 3.6-fold (0.55 log units) above the measured one; measured number below the stated range.
By their numbers in this assay, from the lowest: compounds 2, 4, 1 and 3 (each within the scatter of the next, the first and the last beyond it).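

The same change, methyl in place of hydrogen, does not push the number the same way at every place: on a saturated chain carbon bound to a saturated chain carbon and a saturated ring carbon, this assay shows a 2.9-fold lower number from compound 3 to compound 4 (0.46 log units; beyond the scatter). Nor does the number follow the size of the group on the saturated ring carbon in a simple way, since isopropyl in place of methyl gives only a 1.6-fold higher number from compound 2 to compound 4 (0.20 log units; within the scatter), while the ethyl of compound 3 stands clearly apart from the methyl of compound 2. Nothing available explains this turn.

From the compounds shown here alone, whether a longer chain such as propyl or a ring such as cyclopropyl on that carbon would behave like ethyl or like isopropyl stays open. So does whether the same turn appears on the core of compound 1.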